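The source may hold more compounds than are shown below. What is called first, only, known or untested is meant among the compounds shown, and "the series" means these compounds.

Measured so far in a functional assay on MKN-45 cells (Homo sapiens) for cytotoxicity, read by MTT assay, with a stated time of 72 h; a lower number here means a stronger inhibitor, a higher number a weaker inhibitor:
compound 2, `CN(C)CCNc1nc(-c2ccc(NC(=O)Nc3ccccc3)cc2)nc2ccsc12`: compound 2 gives 1120 nM
compound 1, `CN(C)CCCNc1nc(-c2ccc(NC(=O)Nc3ccc(Cl)cc3)cc2)nc2c(Cl)c(Cl)sc12`: compound 1 gives 1530 nM
compound 3, `CN(C)CCNc1nc(-c2ccc(NC(=O)Nc3ccc(Cl)cc3Cl)cc2)nc2c(Cl)c(Cl)sc12`: compound 3 gives 3460 nM

Compound 2 has the lowest number of the three. Compound 1 sits nearest to it, and the gap between the two lies within the scatter, so no order between compound 2 and compound 1 can be read from these numbers. Compound 3 sits furthest away, with a higher number than compound 2 by a gap beyond the scatter; compound 3 and compound 2 differ in more than one place, so nothing is attributed to any single change there.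

Compound 4, `Cc1ccc(NC(=O)Nc2ccc(-c3nc(NCCN(C)C)c4sccc4n3)cc2)cc1`, is not yet measured. It differs from compound 2 in one place: methyl in place of hydrogen on an aromatic carbon. Among the compounds with values here, no step between measured compounds isolates this change, and neither compound 1 nor compound 3 carries a methyl at that position, so there is no direct precedent. A change of this kind is expected to give no step beyond the scatter in this assay, in either direction. Compound 4 is therefore expected near the number of compound 2, at an estimated 1000 nM with a range from 400 nM to 2500 nM, which corresponds to an expected step of a 1.1-fold lower number from compound 2 to compound 4 (0.05 log units; within the scatter).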

Compound 4, half-maximal inhibitory concentration: 2380 nM
Compound 4: middle estimate off by 2.4-fold (0.38 log units), on the low side; the range from low to high includes it.
By their numbers in this assay, from the lowest: compounds 2, 1, 4 and 3 (each within the scatter of the next, the first and the last beyond it).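

In this assay, within the data shown here, the change from phenylcarbamoyl to (4-methylphenyl)carbamoyl gives a 2.1-fold higher number from compound 2 to compound 4 (0.33 log units; beyond the scatter), the first step that isolates a single change. The position on the six-membered aromatic ring, para to a large group, is therefore not silent in this assay: one added methyl moves the number upward beyond the scatter, though only modestly. No measurement on hand bears on the origin of this step.

It remains open whether the higher number is particular to methyl or would also follow from other groups in this place, such as methoxy, fluorine, an amine or a carboxylic acid, none of which is among the compounds shown. Compound 1 and compound 3 both carry chlorine at this position, but each differs from compound 2 in more than one place, so they do not show how chlorine alone compares with hydrogen or methyl here.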